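Trading a Methyl for Hydrogen on a Shared Core

The compounds below may be only part of what the source reports. "The series", "measured", "known", "first", "only" and "open" are said of these compounds alone.

Four compounds are built on one shared core. Compound 1 `COc1cc(-c2nn(-c3cccc(NC(=O)Nc4cc(C(F)(F)F)cc(C(F)(F)F)c4)c3)cc2-c2ccncc2)ccc1Cl` is the starting point. In a functional assay on NCI-H226 cells (Homo sapiens) for inhibition, read by sulforhodamine B assay, with a stated time of 48 h (a lower number here means a stronger inhibitor of growth, a higher number a weaker inhibitor of growth), compound 1 gives 21800 nM. Compound 2 `O=C(Nc1cccc(-n2cc(-c3ccncc3)c(-c3ccc(Cl)c(O)c3)n2)c1)Nc1cc(C(F)(F)F)cc(C(F)(F)F)c1` differs from compound 1 only by hydrogen in place of methyl on an oxygen on an aromatic ring. In this assay compound 2 gives 6120 nM, and the step is a 3.6-fold lower number from compound 1 to compound 2 (0.55 log units; beyond the scatter).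

Compound 3 `COc1cc(-c2nn(-c3cccc(NC(=O)Nc4ccc(Cl)c(C(F)(F)F)c4)c3)cc2-c2ccncc2)ccc1Cl` carries a different core; the difference between the cores of compound 1 and compound 3 is not broken down here. In this assay compound 3 reaches only a limit, > 32500 nM. This is the limit of > 32500 nM in this assay, at which 1 of the 3 values shown sits.

Compound 4 `O=C(Nc1cccc(-n2cc(-c3ccncc3)c(-c3ccc(Cl)c(O)c3)n2)c1)Nc1ccc(Cl)c(C(F)(F)F)c1` is not yet measured. It differs from compound 3 by hydrogen in place of methyl on an oxygen on an aromatic ring, the same change as that from compound 1 to compound 2, at the same kind of place.

The expected step is an at least 2.1-fold lower number from compound 3 to compound 4 (0.33 log units; beyond the scatter), resting on a 3.6-fold lower number from compound 1 to compound 2 (0.55 log units; beyond the scatter). Because compound 3 shows only > 32500 nM the starting level is uncertain. Compound 4 is estimated at 15000 nM, between 4500 nM and 40000 nM.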

Compound 4, concentration for total growth inhibition: > 32500 nM
Compound 4 ended at the assay's limit (the forecaster's own chance of this, stated with the estimate: 40%); at least 2.1-fold (0.33 log units) between middle value and limit.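

Compound 3 and compound 4 both end at the same limit in this assay, so no step between them can be read: the limit of > 32500 nM in this assay, at which 2 of the 4 values shown sit.

The compounds shown leave open whether methoxy to hydroxy, which gave a 3.6-fold lower number from compound 1 to compound 2 (0.55 log units; beyond the scatter), changes growth inhibition at all when the core is that of compound 3.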